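Amino in Place of Hydroxy on an Oxime-Type Nitrogen

The source may hold more compounds than are shown below. What is called first, only, known or untested is meant among the compounds shown, and "the series" means these compounds.

Of the compounds shown here, two built on a shared core have been tested in a functional assay on the whole organism (strain albino) for inhibition, with Rattus norvegicus as the target, read by paw edema, with a stated time of 4 h, at a dose of 0.029 mmol/kg by the oral route; a higher number here means more inhibition at the dose given (going by the name of the read-out), a lower number less inhibition. Compound 1 `N#Cc1c2n(c(=O)n(-c3ccccc3)/c1=N\CCO)CCC2` gives 1% there, which is close to no effect at the dose used. Compound 2 `NC1=C(/C(N)=N\O)C2CCCN2C(=O)N1c1ccccc1` gives 1% in this assay, level with compound 1 within the scatter, so the two cannot be told apart on these numbers.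

Compound 3 `N/N=C(/N)C1=C(N)N(c2ccccc2)C(=O)N2CCCC12` has not been measured yet. It differs from compound 2 in one place: amino in place of hydroxy on a double-bonded nitrogen. Going by the values given here, no pair of measured compounds shows what this exchange does, so nothing measured supports a step in either direction. Because compound 2 gives 1%, close to no effect at the dose used, compound 3 is expected to stay within the scatter rather than move beyond it. The expected value for compound 3 is 3%, with a range from 0% to 15%. The estimated step of a number 2 percentage points higher from compound 2 to compound 3 (within the scatter) is expected to lie within the scatter.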

Compound 3, a percentage reported as inhibition, in the whole organism at one dose (the size of the read-out at that dose, not a potency): 0.84%
Beside the measured number, compound 3's estimate is 2.2 percentage points above it; low and high end bracket the measured number.
By their numbers in this assay, from the lowest: compounds 3, 1 and 2 (each within the scatter of the next).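

In this assay, going by these compounds alone, amino in place of hydroxy on a double-bonded nitrogen gives a number 0.2 percentage points lower from compound 2 to compound 3 (within the scatter) and so provides the first measured pair that isolates this exchange. Within the data shown here, the pair shows no separation, and with compound 2 already close to no effect at the dose used, it shows only that this exchange does not bring measurable inhibition at that dose; it cannot show whether the same exchange would matter in a compound with a clear effect. No measured finding bears on this outcome.

Still open, as far as these compounds go, is whether a methoxy or a dimethylamino group on that nitrogen would give a reading beyond the scatter. Also open, from the compounds shown here alone, is how hydroxy and amino would compare at this position on a compound with clear inhibition.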